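An aryl exchange from compound 2 to compound 4

The compounds below may be only part of what the source reports. "The series", "measured", "known", "first", "only" and "open" are said of these compounds alone.

In a functional assay on MCF7 cells (Homo sapiens) for antiproliferative activity, read by MTT assay, with a stated time of 24 h (a higher number here means a weaker inhibitor of growth, a lower number a stronger inhibitor of growth), compound 2 (`NC(=S)N1N=C(c2ccc(Br)cc2)CC1c1ccc2ccccc2c1`) gives 440 nM and lies within the scatter of compound 3 (`c1ccc(C2=NN(c3ccccc3)C(c3ccc4ccccc4c3)C2)cc1`) at 730 nM and of compound 1 (`Fc1ccc(C2=NN(c3ccccc3)C(c3ccc4ccccc4c3)C2)cc1`) at 850 nM on the same read-out. Compound 4 (`NC(=S)N1N=C(c2ccc(Cl)c(Cl)c2)CC1c1ccc2ccccc2c1`) differs from compound 2 in one place: 3,4-dichlorophenyl in place of 4-bromophenyl on a carbon with a double bond to nitrogen with 3,4-dichlorophenyl in place of 4-bromophenyl on a carbon with a double bond to nitrogen. Within the data shown here, the only measured step that touches a halogen on such an aryl group is a 1.2-fold lower number from compound 1 to compound 3 (0.07 log units; within the scatter) and it stays within the scatter, although it belongs to a different core and concerns hydrogen in place of fluoro. Among the measured compounds shown here, no measured step covers bromo or chloro on the core of compound 2, so this evidence is indirect. The expected step is a 1.1-fold higher number from compound 2 to compound 4 (0.04 log units; within the scatter) and so no step beyond the scatter is expected in this assay for this exchange. For compound 4 the estimate is 480 nM with 200 nM to 1100 nM as the expected range.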

Compound 4, concentration for 50% growth inhibition: 350 nM
Compound 4: the middle estimate sits 1.4-fold (0.14 log units) above what was measured; the range from low to high includes it.
By their numbers in this assay, from the lowest: compounds 4, 2, 3 and 1 (each within the scatter of the next, the first and the last beyond it).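

In this assay, among these compounds, the exchange of 4-bromophenyl for 3,4-dichlorophenyl on the carbon with a double bond to nitrogen gives a 1.3-fold lower number from compound 2 to compound 4 (0.10 log units; within the scatter), the first measured step on the core of compound 2. Among the compounds shown here, the position therefore accepts a chlorine pair in place of a single bromine with no shift beyond the scatter, something the earlier compounds could not show, since their only step lay on a different core and concerned fluoro. No measured evidence here explains why the two aryl groups read alike.

As far as these compounds go, it remains open whether this position would also accept a phenyl ring carrying an amine or a carboxylic acid instead of halogens. From the compounds shown here alone, whether the same exchange would read alike on the core of compound 1 also remains open.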